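A few compounds are considered here, and "the series" means these few. Any claim that something is new, unique, unknown or untested is made for them only; others in the source may bear on it.

Measured compounds in the series:
compound 1 `CC1=CCC[C@H]2[C@](C)(CC3=CC(=O)C=CC3=O)[C@@H](C)CC[C@]12C`: 4500 nM
compound 2 `COC1=CC(=O)C=C(C[C@]2(C)[C@@H](C)CC[C@]3(C)C(C)=CCC[C@@H]23)C1=O`: 5500 nM
compound 3 `CC1=CCC[C@H]2[C@](C)(CC3=CC(=O)C=C(Sc4ccccc4)C3=O)[C@@H](C)CC[C@]12C`: "not determined" (no result reported)

In an ADME assay on PBMC cells (Homo sapiens) for inhibition, read by MTT assay (on this read-out higher numbers stand for weaker inhibition and lower numbers for stronger inhibition), compound 1 gives 4500 nM and compound 2 gives 5500 nM. For the measured compounds named here, the only one-place step measured so far is a 1.2-fold higher number from compound 1 to compound 2 (0.09 log units; within the scatter), a change at the same ring carbon that is varied below. Compound 3 has no number in this assay, so it cannot be placed against compound 1 or compound 2 on the numbers shown. Compound 4 `CNC1=CC(=O)C=C(C[C@]2(C)[C@@H](C)CC[C@]3(C)C(C)=CCC[C@@H]23)C1=O` differs from compound 3 by methylamino in place of phenylsulfanyl on a double-bonded ring carbon. Going by the values given here, no measured step covers this change, and with no number for compound 3 the size of the step cannot be computed. The nearest comparison is compound 2, which carries methoxy on the ring carbon where compound 4 carries methylamino. Since compound 2 gives 5500 nM and the step of a 1.2-fold higher number from compound 1 to compound 2 (0.09 log units; within the scatter) stayed within the scatter, a number close to those of compound 1 and compound 2 is expected in this assay. Compound 4 is therefore estimated at 5000 nM in this assay, with a range of 1500 nM to 15000 nM.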

Compound 4, half-maximal inhibitory concentration: 4200 nM
For compound 4 the middle estimate is 1.2-fold (0.08 log units) above the measured one; measured number inside the range.
By their numbers in this assay, from the lowest: compounds 4, 1 and 2 (each within the scatter of the next).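

In this assay, methylamino on this double-bonded ring carbon gives a 1.3-fold lower number from compound 2 to compound 4 (0.12 log units; within the scatter) and a 1.1-fold lower number from compound 1 to compound 4 (0.03 log units; within the scatter). Hydrogen, methoxy and methylamino at this ring carbon therefore cannot be told apart on these numbers, so the earlier flat step now holds for a second group on the shared core. Steps involving compound 3 cannot be read, and no measured information is available to explain the flat result.

As far as these compounds go, whether any group at this ring carbon can move the number beyond the scatter remains open, for example a dimethylamino group, a carboxylic acid or a longer alkylamino chain. From the compounds shown here alone, it also remains open where phenylsulfanyl, with its six-membered aromatic ring, stands against hydrogen, methoxy and methylamino.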